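The source may hold more compounds than are shown below. What is called first, only, known or untested is meant among the compounds shown, and "the series" means these compounds.

Measured so far:
compound 1 `COc1cc(-c2nn(-c3cccc(NC(=O)Nc4cc(C(F)(F)F)cc(C(F)(F)F)c4)c3)cc2-c2ccncc2)ccc1Cl` — 869 nM
compound 2 `COc1cc(-c2nn(-c3cccc(NC(=O)c4cccc(C(F)(F)F)c4)c3)cc2-c2ccncc2)ccc1Cl` — 811 nM
compound 3 `O=C(Nc1cccc(-n2cc(-c3ccncc3)c(-c3ccc(Cl)c(O)c3)n2)c1)Nc1ccc(Cl)c(Cl)c1` — 1000 nM

In a functional assay on RXF 393 cells (Homo sapiens) for inhibition, read by sulforhodamine B assay, with a stated time of 48 h (a higher number here means a weaker inhibitor of growth, a lower number a stronger inhibitor of growth), compound 2 gives 811 nM, the lowest of the three numbers, but compound 1 with 869 nM and compound 3 with 1000 nM both lie within the usual scatter of it, so the three measured compounds cannot be ranked against one another. All three sit around the same level in this assay.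

Compound 4 `COc1cc(-c2nn(-c3cccc(NC(=O)c4ccc(Cl)c(C(F)(F)F)c4)c3)cc2-c2ccncc2)ccc1Cl` is not yet measured. It differs from compound 2 in a single place: chloro in place of hydrogen on an aromatic carbon. Within the data shown here, no pair of measured compounds differs in the same way, so there is no step from which the size of this change could be read. Among the measured compounds shown here, with the three measured numbers so close together and no comparable step available, the expectation is a change of small size, if any, with no direction beyond the scatter.

The estimate for compound 4 in this assay is 700 nM, with a range from 300 nM to 1800 nM. This estimate amounts to a 1.2-fold lower number from compound 2 to compound 4 (0.06 log units; within the scatter), a step expected to stay within the scatter.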

Compound 4, concentration for 50% growth inhibition: 1760 nM
Compound 4: the middle estimate sits 2.5-fold (0.40 log units) below what was measured, within the range that was stated.
By their numbers in this assay, from the lowest: compounds 2, 1, 3 and 4 (each within the scatter of the next, the first and the last beyond it).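

In this assay, among these compounds, chloro in place of hydrogen on the aromatic carbon ortho to the trifluoromethyl group gives a 2.2-fold higher number from compound 2 to compound 4 (0.34 log units; beyond the scatter), the only step in this set that can be read between two compounds differing in one place. The change from 3-(trifluoromethyl)phenyl to 4-chloro-3-(trifluoromethyl)phenyl therefore shows that this position is not indifferent to substitution, and that chloro here goes with a weaker inhibitor of growth. No measurement at hand accounts for this step.

On these data alone, whether fluoro, methoxy or an amine on the same carbon would shift the number in the same direction remains open. Also open, as far as these compounds go, is whether chloro at this position would give a step of similar size in the setting of compound 1, whose side chain differs from that of compound 2.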